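The source may report more compounds than this note shows. Statements on the series, on what has been measured and on what is new or still open speak of the compounds shown alone.

Compound 1, `COC(=O)c1cc(-c2csc(N/N=C/c3cccs3)n2)ccc1OCc1ccccc1`, gives 96% in a functional assay, read by spectrophotometry, with a stated time of 15 min, tested at 80 ug/mL; a lower number here means a weaker effect, a higher number a stronger effect of the compound at the concentration tested. Compound 2, `Fc1ccc(-c2csc(N/N=C/c3ccc(Cl)cc3Cl)n2)cc1`, gives 95.5% in this assay. Compound 2 stands lowest of the two numbers shown, but its only neighbour, compound 1, lies higher by an amount within the scatter, so the two measured compounds cannot be told apart on these numbers; both sit close to full inhibition at the concentration tested.

Compound 3, `COc1ccc(-c2csc(N/N=C/c3ccc(Cl)cc3Cl)n2)cc1`, has not yet been measured in this assay. It differs from compound 2 in one place: methoxy in place of fluoro on an aromatic carbon. Going by the values given here, no pair of measured compounds differs by methoxy in place of fluoro, so there is no measured step to lean on for the size of this change.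

Because compound 2 reaches 95.5% and compound 1 reaches 96%, both measured numbers already stand high, and little room is left for compound 3 to rise further. For compound 3 the expected step is a number 3.5 percentage points lower from compound 2 to compound 3 (within the scatter). Compound 3 is estimated to give 92% in this assay, with a range from 78% to 98%.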

Compound 3, a percentage reported as inhibition, at one concentration (the size of the read-out at that concentration, not a potency): 90.6%
Estimate against measurement, compound 3: 1.4 percentage points above, and the stated range covers the measured number.
By their numbers in this assay, from the lowest: compounds 3, 2 and 1 (each within the scatter of the next).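

In this assay, a number 4.9 percentage points lower from compound 2 to compound 3 (within the scatter) comes with methoxy in place of fluoro on an aromatic carbon, so this first single-place comparison gives a step that cannot be told from repeat scatter. At this place on the six-membered aromatic ring, para to a large group, the read-out therefore does not separate 4-fluorophenyl from 4-methoxyphenyl, even though the entering group brings one more heavy atom and a hydrogen-bond acceptor that fluoro does not count. No measurement is at hand that gives a reason for this result.

The compounds shown leave open whether an amine, a carboxylic acid or a longer chain such as butoxy at this same place would also stay within the scatter of compound 2, since fluoro and methoxy are the only two groups compared here. They also leave open whether fluoro and methoxy would differ at other concentrations, since a read-out at one concentration is not a potency and says nothing of how the two compare when inhibition is far from complete.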